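Oxazole ketones as diacylglycerol lipase-alpha inhibitors: phenyl for acetyl

This account rests on a few compounds, and the source may have more. Where it says the series, first, only, none or still open, it means among the compounds named here.

Measured so far:
compound 1 `O=C(CCCCCc1ccccc1)c1nc2ccccc2[nH]1` 12000 nM
compound 2 `CC(=O)c1coc(C(=O)CCCCCCc2ccccc2)n1` 123 nM

Compound 2 carries the lower of the two numbers in an assay on HEK-293T cells for inhibition of diacylglycerol lipase-alpha (Homo sapiens), read by colorimetric assay; on this read-out lower numbers stand for stronger inhibition and higher numbers for weaker inhibition; compound 1 gives a number higher by a margin well beyond the scatter. Compound 3 `O=C(CCCCCCc1ccccc1)c1nc(-c2ccccc2)co1` is the next analogue, differing from compound 2 only as phenyl in place of acetyl on an aromatic carbon. Within the data shown here, no measured pair isolates this change, so its size is not anchored by any step already known. The expectation is a step of a 1.2-fold lower number from compound 2 to compound 3 (0.09 log units; within the scatter), within or at the edge of the scatter. Compound 3 is therefore estimated at 100 nM, plausibly between 30 nM and 400 nM.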

Compound 3, half-maximal inhibitory concentration: 8710 nM
Beside the measured number, compound 3's estimate is 87-fold (1.94 log units) below it, outside the stated range (above it).
By their numbers in this assay, from the lowest: compound 2; then compounds 3 and 1 (each within the scatter of the next).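

In this assay the aromatic carbon next to the ring nitrogen is sensitive to its substituent: phenyl in place of acetyl gives a 71-fold higher number from compound 2 to compound 3 (1.85 log units; beyond the scatter) in this series. This first step at the position shows that exchanging acetyl, with its hydrogen-bond acceptor, for an aromatic ring of carbon only is far from a neutral swap. Nothing measured here bears on the cause of the step.

Open, going by these compounds, is whether the step follows from losing acetyl or from gaining phenyl. A methyl ester, a primary amide or a nitrile on this carbon would help separate the two.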